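Working notes: changing the aryl group of compound 2

This account rests on a few compounds, and the source may have more. Where it says the series, first, only, none or still open, it means among the compounds named here.

Measured in a functional assay on MCF7 cells (Homo sapiens) for cytotoxicity, read by CellTiter-Glo, with a stated time of 5 days; a higher number here means a weaker inhibitor, a lower number a stronger inhibitor:
- compound 1 `CC/C(=C(/c1ccc(/C=C/C(=O)O)cc1)c1ccc2[nH]ncc2c1)c1ccccc1C#N`: 12 nM
- compound 2 `CC/C(=C(/c1ccc(/C=C/C(=O)O)cc1)c1ccc2[nH]ncc2c1)c1ccc(C#N)cc1Cl`: 4 nM

Of the two measured compounds, compound 2 stands lowest, at 4 nM. Compound 3 `CC/C(=C(/c1ccc(/C=C/C(=O)O)cc1)c1ccc2[nH]ncc2c1)c1ccncc1C` changes the same position: 3-methylpyridin-4-yl in place of 2-chloro-4-cyanophenyl on a double-bonded chain carbon bound to a double-bonded chain carbon and a saturated chain carbon. Going by the values given here, the only measured step there, a 3.0-fold lower number from compound 1 to compound 2 (0.48 log units; beyond the scatter), is modest but beyond the scatter. Both measured compounds carry a nitrile on this group, whereas compound 3 has none, so a modest rise of similar size is expected in this assay. The expected change is a 3.0-fold higher number from compound 2 to compound 3 (0.48 log units; beyond the scatter). For compound 3 the estimated value is 12 nM, with an expected range of 3 nM to 50 nM.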

Compound 3, half-maximal inhibitory concentration: 16 nM
Estimate against measurement, compound 3: 1.3-fold (0.12 log units) below, within the range that was stated.
By their numbers in this assay, from the lowest: compound 2; then compounds 1 and 3 (each within the scatter of the next).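

In this assay, the nitrile proves dispensable at this position, since 3-methylpyridin-4-yl carries none: replacing 2-chloro-4-cyanophenyl gives a 4.0-fold higher number from compound 2 to compound 3 (0.60 log units; beyond the scatter), and replacing 2-cyanophenyl gives a 1.3-fold higher number from compound 1 to compound 3 (0.12 log units; within the scatter). Among these three groups, only 2-chloro-4-cyanophenyl stands apart, while a ring with a hetero atom and no nitrile sits level with 2-cyanophenyl. Nothing available accounts for these differences. From the compounds shown here alone, whether the chlorine alone separates compound 2 from the others remains open, as does how a methoxy group or an amine on this ring would read.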